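A few compounds are considered here, and "the series" means these few. Any claim that something is new, unique, unknown or untested is made for them only; others in the source may bear on it.

Measured compounds:
- compound 1 `O=C(CCCCC1CCSS1)NO`: "not active" (no number reported)
- compound 2 `O=C(CCCCC1CCSS1)Nc1ccc([N+](=O)[O-])c(C(F)(F)F)c1`: "not active" (no number reported)
- compound 3 `O=C(CCCCC1CCSS1)Nc1ccccn1`: 1.14%

Of the compounds shown here, three sharing the same core have been tested in a functional assay on HO8910 cells (Homo sapiens) for inhibition, read by MTT assay, with a stated time of 24 h, tested at 0.1 ug/mL; a lower number here means less inhibition of growth, a higher number more inhibition of growth at the concentration tested. For compound 1 and compound 2 the outcome was reported only as not active, without a number. Within the data shown here, compound 3 is therefore the only entry with a number: in this assay compound 3 gives 1.14%, a figure that sits at the bottom of the scale and points to essentially no inhibition of growth at the concentration tested.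

Compound 4 `O=C(CCCCC1CCSS1)Nc1ccc(Br)cn1` differs from compound 3 in one place: bromo in place of hydrogen on an aromatic carbon. Among the measured compounds shown here, no step between two measured compounds is available to show what such a change does, so the expectation rests on compound 3 alone. Given that compound 3 gives 1.14%, the step from compound 3 to compound 4 is expected to be small, a number 1.9 percentage points higher from compound 3 to compound 4 (within the scatter), and within the usual scatter. For compound 4 in this assay the estimated value is 3%, with a range from -8% to 15%.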

Compound 4, percent growth inhibition at one concentration: "not active" (no number reported)
Compound 4: no number reported; the estimate stays without a comparison.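

Among these compounds, compound 4 was reported only as not active, without a number, so no step from compound 3 to compound 4 can be read. The compounds shown leave open whether any group on the aromatic ring of compound 3 measurably changes the outcome in this assay. No other data bear on this result.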